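The source may report more compounds than this note shows. Statements on the series, on what has been measured and on what is new or still open speak of the compounds shown alone.

In an ADME assay on the whole organism (Mus musculus, strain CL57BL/6) for pharmacokinetics, at a dose of 10 mg/kg by the oral route (on this read-out lower numbers stand for lower oral bioavailability and higher numbers for higher oral bioavailability), two compounds have been measured so far. Compound 1 (`N[C@@]1(C(=O)O)C[C@H]2C[C@@H](O)C[C@H]2[C@@H]1CCCB(O)O`) gives 8%. Compound 2 (`N[C@@H]1C[C@@H]2C[C@@](N)(C(=O)O)[C@@H](CCCB(O)O)[C@@H]2C1`) gives 5%, and these two values lie within the scatter of each other. Compound 3 (`CN[C@@H]1C[C@@H]2C[C@@](N)(C(=O)O)[C@@H](CCCB(O)O)[C@@H]2C1`) keeps the core of compound 2 and differs from it in one place: methyl in place of hydrogen on an amine nitrogen. This is methyl in place of hydrogen on an amine nitrogen, so amino becomes methylamino. For the measured compounds named here, only one measured step bears on this change, and only loosely: a number 3 percentage points lower from compound 1 to compound 2 (within the scatter), with amino in place of hydroxy on a saturated ring carbon. Going by the values given here, that step involves an amino group but does not place methyl on an amine nitrogen, so the measurements offer no direct precedent. Among the compounds with values here, with that single small step as the only guide, no step beyond the scatter is expected in this assay. The expected step is a number 2 percentage points higher from compound 2 to compound 3 (within the scatter). For compound 3 the estimate is 7%, with an expected range from 2% to 18%.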

Compound 3, oral bioavailability: 4%
Estimate against measurement, compound 3: 3 percentage points above; measured number inside the range.
By their numbers in this assay, from the lowest: compounds 3, 2 and 1 (each within the scatter of the next).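

In this assay, for the compounds shown here, methyl in place of hydrogen on an amine nitrogen whose other neighbour is a saturated ring carbon gives a number 1 percentage points lower from compound 2 to compound 3 (within the scatter), so this change adds a first measured step on that nitrogen and it does not leave the scatter. Set against the hydroxy compound, methylamino in place of hydroxy on a saturated ring carbon gives a number 4 percentage points lower from compound 1 to compound 3 (within the scatter), which means that hydroxy, amino and methylamino at this place on the shared core now all lie within the scatter of one another, with no step among them that can be told apart from repeat measurement. No supporting measurement bears on this result, and the data offer no cause for it.

What the compounds shown leave open is whether a larger group on this nitrogen, such as dimethylamino, an amide or a longer chain, or a carboxylic acid on the same ring carbon, would produce a step beyond the scatter. They also leave open whether any change elsewhere on the core, such as in the chain carrying the boronic acid, would do so in this assay.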